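Triazole series on prostate cells: replacing the ether arm

The source may report more compounds than this note shows. Statements on the series, on what has been measured and on what is new or still open speak of the compounds shown alone.

Measured so far:
compound 1 `CS(=O)(=O)Nc1ccc(-n2cc(COc3ccc([N+](=O)[O-])cc3)nn2)cc1Oc1ccccc1`, 7200 nM
compound 2 `CS(=O)(=O)Nc1ccc(-n2cc(COc3ccc4ccccc4c3)nn2)cc1Oc1ccccc1`, 9100 nM

Both compounds were read in a functional assay on DU-145 cells (Homo sapiens) for inhibition, read by MTT assay, with a stated time of 48 h; a higher number here means a weaker inhibitor, a lower number a stronger inhibitor. Compound 1 gives 7200 nM, the lower of the two numbers. Compound 2 gives 9100 nM, and the step of a 1.3-fold higher number from compound 1 to compound 2 (0.10 log units; within the scatter) says the two sit within the scatter of each other, so swapping the aryl group on the ether oxygen left the read-out unchanged.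

Compound 3 `Cc1ccc(-c2cn(-c3ccc(NS(C)(=O)=O)c(Oc4ccccc4)c3)nn2)cc1` is not yet measured. Its change from compound 1 is 4-methylphenyl in place of (4-nitrophenoxy)methyl on an aromatic carbon. Among the compounds with values here, the only comparison in hand, a 1.3-fold higher number from compound 1 to compound 2 (0.10 log units; within the scatter), bears on this change just in part: it shows that the aryl ring on the ether oxygen can be exchanged without effect, but it says nothing about removing the oxygen and the saturated carbon between the core and the ring, which is what happens in compound 3. Within the data shown here, there is no measured precedent for that. The expectation is therefore for no step beyond the scatter in this assay, and compound 3 is estimated at 9000 nM, with a range from 3000 nM to 30000 nM. The step this implies, a 1.3-fold higher number from compound 1 to compound 3 (0.10 log units; within the scatter), is expected to be small.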

Compound 3, half-maximal inhibitory concentration: 11200 nM
Estimate against measurement, compound 3: 1.2-fold (0.09 log units) below; measured number inside the range.
By their numbers in this assay, from the lowest: compounds 1, 2 and 3 (each within the scatter of the next).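

In this assay, placing 4-methylphenyl on the aromatic carbon of the five-membered aromatic ring with 3 nitrogen, in place of (4-nitrophenoxy)methyl, gives a 1.6-fold higher number from compound 1 to compound 3 (0.19 log units; within the scatter). The earlier comparison exchanged only the aryl ring on the ether oxygen, whereas this change also removes the oxygen and the saturated carbon, so the read-out at this position does not depend on keeping that ether arm, at least for these compounds. The data offer no measured reason why the read-out stays within the scatter across this change.

Within the data shown here, all three arms end in a six-membered aromatic ring of carbon only, and no step so far lies beyond the scatter, so it remains open whether an amine, a carboxylic acid or a longer chain at this carbon would move the number beyond it in either direction. On these data alone, the shared core is identical in all three compounds, so what its parts contribute to the read-out also remains open.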